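Ethoxy in place of chloro: a step without precedent

The compounds below may be only part of what the source reports. "The series", "measured", "known", "first", "only" and "open" are said of these compounds alone.

Compound 1 `Cc1nc(-c2ccccc2)c(C(=O)N2CCN(c3cccc(Cl)c3)CC2)o1` is the parent of this small set. In a functional assay on HL-60 cells (Homo sapiens) for inhibition, read by MTT assay, with a stated time of 72 h (a higher number here means a weaker inhibitor, a lower number a stronger inhibitor), compound 1 gives 39.2 nM, the middle of three numbers. Compound 2 `Cc1nc(-c2cccc(F)c2)c(C(=O)N2CCN(c3cccc(Cl)c3)CC2)o1` carries fluoro in place of hydrogen and gives 33.7 nM; the step is a 1.2-fold lower number from compound 1 to compound 2 (0.07 log units; within the scatter). Compound 3 `Cc1nc(-c2ccccc2Cl)c(C(=O)N2CCN(c3cccc(Cl)c3)CC2)o1` carries chloro in place of hydrogen and gives 132 nM; the step is a 3.4-fold higher number from compound 1 to compound 3 (0.53 log units; beyond the scatter), and from compound 2 to compound 3 it is a 3.9-fold higher number from compound 2 to compound 3 (0.59 log units; beyond the scatter). All three measured changes sit on the aryl group attached to the shared core.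

Compound 4 `CCOc1cccc(N2CCN(C(=O)c3oc(C)nc3-c3ccccc3)CC2)c1` moves the change to the other end of the molecule: ethoxy in place of chloro on an aromatic carbon. The same difference, cut one bond further out, reads 3-chlorophenyl to 3-ethoxyphenyl. Going by the values given here, no measured step touches this ring, so none bears on the step from compound 1 to compound 4; the three known steps only show that one ring tolerates fluoro and loses modestly with chloro, which says nothing about an ethoxy here. The direction in this assay is therefore open, and the expected size is uncertain rather than large. Compound 4 is estimated at 50 nM, with a range of 15 nM to 200 nM, which is expected to mean a 1.3-fold higher number from compound 1 to compound 4 (0.11 log units; within the scatter).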

Compound 4, half-maximal inhibitory concentration: 151 nM
Beside the measured number, compound 4's estimate is 3.0-fold (0.48 log units) below it, within the range that was stated.
By their numbers in this assay, from the lowest: compounds 2 and 1 (each within the scatter of the next); then compounds 3 and 4 (each within the scatter of the next).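

In this assay, going by these compounds alone, a 3.9-fold higher number from compound 1 to compound 4 (0.59 log units; beyond the scatter) gives the first measured reading at the 3-chlorophenyl end of the series, and it shows that this position is sensitive to the group it carries. Chloro, with 1 heavy atom and no hydrogen-bond acceptor, gives way to ethoxy, with 3 heavy atoms and 1 hydrogen-bond acceptor, and compound 4 still gives 151 nM, so this change costs only a modest step and leaves a nanomolar number in place. No measurement among those at hand accounts for the size or direction of this step.

Within the data shown here, the single change leaves open whether the step follows the oxygen, the length of the chain or the loss of chloro, and methoxy, a longer chain such as propoxy, or an amine such as dimethylamino on the same aromatic carbon would begin to separate these readings. Also open, going by these compounds, is whether ethoxy at this position gives a similar step when paired with the 3-fluorophenyl or 2-chlorophenyl groups at the other end of the molecule, which would show whether changes at the two ends act independently.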